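A few compounds are considered here, and "the series" means these few. Any claim that something is new, unique, unknown or untested is made for them only; others in the source may bear on it.

Compound 2 `Cc1oc(-c2ccc(Cl)cc2)nc1CN1CCC(C(=O)NCCCN2C[C@H](C)C[C@H](C)C2)CC1` is the starting point of this step. Within the data shown here, in an ADME assay on microsomes from liver (Rattus norvegicus) for metabolic stability, read by LC-MS, using NADPH, at 37 degrees C (on this read-out higher numbers stand for a longer-lived compound and lower numbers for a shorter-lived compound), compound 2 gives only a limit of the assay, > 0.5 h, not a number; it is the one compound of the three that sits at the limit of > 0.5 h in this assay, at which 1 of the 3 values shown sits. Its companions are compound 1 `CC[C@@H]1C[C@H](CC)CN(CCCNC(=O)C2CCN(Cc3nc(-c4ccccc4C)oc3C)CC2)C1`, which in this assay gives 0.0917 h, and compound 3 `Cc1ccccc1-c1nc(CN2CCC(C(=O)NCCCN3CC4CCCC(C4)C3)CC2)c(C)o1`, which gives 0.123 h. Among the measured compounds shown here, the one step measured between these compounds, a 1.3-fold higher number from compound 1 to compound 3 (0.13 log units; within the scatter), changes the amine ring at the far end of the chain and leaves the aryl group on the five-membered ring untouched.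

Compound 4 `Cc1ccc(-c2nc(CN3CCC(C(=O)NCCCN4C[C@H](C)C[C@H](C)C4)CC3)c(C)o2)cc1C` differs from compound 2 in that aryl group: 3,4-dimethylphenyl in place of 4-chlorophenyl on an aromatic carbon

No measured step touches this position, so nothing among the shown numbers tells how large a change to expect in this assay, in either direction. What remains is the limit of compound 2, and the estimate for compound 4 is placed with wide spread below it. Compound 4 is expected to give 0.3 h, between 0.1 h and 0.7 h, which corresponds to an expected step of an at least 1.6-fold lower number from compound 2 to compound 4 (0.22 log units; that floor lies within the scatter).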

Compound 4, half-life: > 0.5 h
Compound 4: only a limit was reported; the forecaster's own chance of this, stated with the estimate: 30%; middle value at least 1.6-fold (0.22 log units) away from the limit.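

In this assay compound 4, like compound 2, gives only a limit, so no step between the two can be read: the limit of > 0.5 h in this assay, at which 2 of the 4 values shown sit.

From the compounds shown here alone, how far either compound lies past that limit, and so what 3,4-dimethylphenyl in place of 4-chlorophenyl changes in half-life, stays open.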